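Replacing an acetoxymethyl tail with phenyl in compound 1

A few compounds are considered here, and "the series" means these few. Any claim that something is new, unique, unknown or untested is made for them only; others in the source may bear on it.

Compound 1, with structure `CC(=O)OCCOCN1c2ccccc2C(=O)NS1(=O)=O`, has been tested in a functional assay on HEL cells (Homo sapiens) for cytotoxicity; on this read-out lower numbers stand for higher toxicity in this test and higher numbers for lower toxicity in this test. In this assay compound 1 gives > 50 ug/mL, which is a limit of the assay and not a number. Two related compounds were measured alongside it. Compound 2, with structure `O=C1c2ccccc2NS(=O)(=O)N1Cc1ccccc1`, gives 50 ug/mL in this assay. Compound 3, with structure `CC(=O)OCCOCN1c2ccccc2C(=O)N(Cc2ccccc2)S1(=O)=O`, gives 50 ug/mL in this assay. On these data alone, the step with benzyl in place of hydrogen on an amide-type nitrogen in a ring reads a number no higher from compound 1 to compound 3 (the limit leaves the size open), and its size stays open because of the limit of > 50 ug/mL in this assay, at which 1 of the 3 values shown sits. The step with (2-acetoxyethoxy)methyl in place of hydrogen on a sulfonamide nitrogen in a ring reads no change at the digits printed from compound 2 to compound 3 (within the scatter).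

The unmeasured compound 4 has structure `O=C1NS(=O)(=O)N(COCc2ccccc2)c2ccccc21`. It differs from compound 1 by phenyl in place of acetoxymethyl on a saturated chain carbon bound to an oxygen on a saturated carbon. Neither measured step covers this exact change, but both steps leave the values of compounds 2 and 3 where they stand, and both touch the groups hanging from the ring nitrogens without moving the read-out. The expectation is therefore that this change in the side chain changes little, so the estimated step of a number no higher from compound 1 to compound 4 (the limit leaves the size open) is close to none beyond the scatter. Compound 4 is expected to give about 50 ug/mL in this assay, with a range from 25 ug/mL to 100 ug/mL.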

Compound 4, minimum cytotoxic concentration: > 50 ug/mL
Compound 4: no number, only a limit; the forecaster's own chance of this, stated with the estimate: 50%; the middle value lies on the limit itself.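

In this assay compound 4 gives > 50 ug/mL as a limit of the assay and not a number. Within the data shown here, compound 1 also sits at a limit, so no step from compound 1 to compound 4 can be read: the limit of > 50 ug/mL in this assay, at which 2 of the 4 values shown sit. The compounds shown leave open whether phenyl in place of acetoxymethyl changes this read-out at all, and by how much.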